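The source may report more compounds than this note shows. Statements on the series, on what has been measured and on what is new or still open speak of the compounds shown alone.

Measured so far:
- compound 1 `CC(O)(C(=O)Nc1ccc(S(=O)(=O)c2ccccc2)c(C#N)c1)C(F)(F)F`: 3800 nM
- compound 2 `CC(O)(C(=O)Nc1ccc(S(=O)(=O)c2ccccc2C#N)cc1)C(F)(F)F`: 1100 nM

Both numbers come from a functional assay (Cavia porcellus) with sulfonylurea receptors; K-ATP channels (Homo sapiens) as the target; a higher number here means a weaker inhibitor, a lower number a stronger inhibitor. Compound 1 stands at the highest of the two numbers; compound 2 sits at a lower number, and the gap between the two values is beyond the usual scatter of this assay. Compound 1 and compound 2 differ in more than one place, so their values show only where each stands, not the size of a single structural step.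

The unmeasured compound 3 `CC(O)(C(=O)Nc1ccc(S(=O)(=O)c2ccccc2)c(C(F)(F)F)c1)C(F)(F)F` is reached from compound 1 by one change: trifluoromethyl in place of cyano on an aromatic carbon. Going by the values given here, no measured pair in this set shows the size of such a step, so the direction cannot be read off anything already measured. With nothing to anchor it, the expectation is a step from compound 1 to compound 3 of a 1.3-fold lower number from compound 1 to compound 3 (0.10 log units; within the scatter) in this assay, which is no more than the scatter, and the estimate for compound 3 in this assay is 3000 nM, within a range from 800 nM to 12000 nM.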

Compound 3, half-maximal inhibitory concentration: > 30000 nM
Compound 3 gave a limit, no number (the forecaster's own chance of this, stated with the estimate: 10%); middle value at least 10-fold (1.00 log units) from the limit.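

In this assay, going by these compounds alone, the only single-place step so far is an at least 7.8-fold higher number from compound 1 to compound 3 (0.89 log units; beyond the scatter), for trifluoromethyl in place of cyano on an aromatic carbon ortho to a phenylsulfonyl group. This position is therefore not indifferent to the group it carries: with the nitrile, compound 1 gives a measurable 3800 nM, while with trifluoromethyl, compound 3 gives no number at all. Compound 3 stands at a limit of the assay, not at a number, and the full size of the step remains unknown: the limit of > 30000 nM in this assay, at which 1 of the 3 values shown sits.

With only one group tested against cyano at this position, the compounds shown do not tell whether the change in compound 3 is particular to trifluoromethyl or would also appear with a chlorine, a methoxy group or an amine on the same carbon. From the compounds shown here alone, compound 2 differs from compound 1 in more than one place, and it remains open whether the same trifluoromethyl for cyano exchange would produce a step of similar size on the core of compound 2.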